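From 5-hydroxypentyl to 2-hydroxyethyl on a shared core

The compounds below may be only part of what the source reports. "The series", "measured", "known", "first", "only" and "open" are said of these compounds alone.

Of the compounds shown here, three built on one core have been measured in an ADME assay on HeLa cells (Homo sapiens) for cytotoxicity, read by sulforhodamine B assay, with a stated time of 48 h, tested at 10 uM; on this read-out lower numbers stand for less inhibition and higher numbers for more inhibition at the one concentration tested (going by the name of the read-out). Compound 1 `COc1nc2ccc(Br)cc2cc1C(c1ccccc1)n1cc(-c2ccccc2F)nn1` gives 14.1%, compound 2 `COc1nc2ccc(Br)cc2cc1C(c1ccccc1)n1cc(-c2cccc(F)c2)nn1` gives 9.04%, and compound 3 `COc1nc2ccc(Br)cc2cc1C(c1ccccc1)n1cc(CCCCCO)nn1` gives 1.08%. Compound 3 stands lowest of the three numbers: a number 8 percentage points lower from compound 2 to compound 3 (within the scatter), whereas a number 13 percentage points lower from compound 1 to compound 3 (beyond the scatter). Between the two fluorophenyl compounds, a number 5.1 percentage points lower from compound 1 to compound 2 (within the scatter).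

Compound 4 `COc1nc2ccc(Br)cc2cc1C(c1ccccc1)n1cc(CCO)nn1` has not yet been measured. Its difference from compound 3 is hydroxy in place of 3-hydroxypropyl on a saturated chain carbon, two bonds along the chain from an aromatic carbon; cut one bond further out, the same change reads 5-hydroxypentyl to 2-hydroxyethyl.

Going by the values given here, none of the measured steps shortens a chain. The two steps in which 5-hydroxypentyl entered at this position, from compound 1 and from compound 2, moved the numbers down by a modest amount or within the scatter, and all three numbers in this assay are low. Among the compounds with values here, with no step bearing directly on chain length, and a low starting point in compound 3, compound 4 is expected to give a number in the same low region. Compound 4 is estimated at 4%, with a range from -6% to 14%. The expected step is therefore a number 2.9 percentage points higher from compound 3 to compound 4 (within the scatter), which would lie within the scatter.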

Compound 4, a percentage reported as inhibition, at one concentration (the size of the read-out at that concentration, not a potency): 0.85%
Estimate against measurement, compound 4: 3.2 percentage points above; measured number inside the range.
By their numbers in this assay, from the lowest: compounds 4, 3, 2 and 1 (each within the scatter of the next, the first and the last beyond it).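

In this assay, going by these compounds alone, the step hydroxy in place of 3-hydroxypropyl on a saturated chain carbon, two bonds along the chain from an aromatic carbon, is the first to bear on chain length at this position, and the two chains cannot be told apart on this read-out (a number 0.2 percentage points lower from compound 3 to compound 4 (within the scatter)). The shorter 2-hydroxyethyl group stands against the two fluorophenyl groups much as 5-hydroxypentyl does: the gap to 2-fluorophenyl lies beyond the scatter (a number 13.3 percentage points lower from compound 1 to compound 4 (beyond the scatter)), while the gap to 3-fluorophenyl does not (a number 8.2 percentage points lower from compound 2 to compound 4 (within the scatter)). Nothing in the data shown accounts for these numbers.

As far as these compounds go, with only the two hydroxy-ended chains in hand, it stays open whether the terminal hydroxy group matters at all, which a plain pentyl chain, or an amine or a carboxylic acid at the chain end, would help to settle. It also stays open whether a longer chain, or hydroxymethyl at the same position, would stay in the same low region, and how any of these compounds would read beyond the one concentration tested.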